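Testing the mirror image of compound 2

This account rests on a few compounds, and the source may have more. Where it says the series, first, only, none or still open, it means among the compounds named here.

Compound 1 `CCOC(=O)[C@]1(C(=O)Nc2ccccc2)C[C@H]1c1cc(OC)c(OC)c(OC)c1`: > 100000 nM
Compound 2 `CCOC(=O)[C@@]1(C(=O)Nc2ccccc2Cl)C[C@@H]1c1cc(OC)c(OC)c(OC)c1`: > 100000 nM

In a functional assay on QGY cells (Homo sapiens) for cytotoxicity, read by MTT assay, with a stated time of 48 h (a lower number here means a stronger inhibitor, a higher number a weaker inhibitor), compound 1 gives > 100000 nM, which is a limit of the assay and not a number. Compound 2 gives > 100000 nM, and this too is only a limit. Compound 2 therefore stands level with the other measured compound, at the limit of > 100000 nM in this assay, at which 2 of the 2 values shown sit.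

The next compound is compound 3 `CCOC(=O)[C@]1(C(=O)Nc2ccccc2Cl)C[C@H]1c1cc(OC)c(OC)c(OC)c1`. The change from its partner is purely one of configuration: the two compounds have the same atoms and bonds and differ only in configuration as drawn: 2 of 2 stereo elements differ (all stereocentres are inverted: mirror images); a stereocentre at a saturated ring carbon is drawn S in compound 2 and R in compound 3; a stereocentre at a saturated ring carbon is drawn R in compound 2 and S in compound 3. The two compounds have the same atoms and bonds and are mirror images.

Within the data shown here, no measured step is available to size such a change. Compound 2 at > 100000 nM is the closest guide, so no step beyond the scatter is expected in this assay, in either direction. The expected change is a number no higher from compound 2 to compound 3 (the limit leaves the size open). For compound 3 the estimated half-maximal inhibitory concentration is 100000 nM, with an expected range of 40000 nM to 200000 nM.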

Compound 3, half-maximal inhibitory concentration: 28000 nM
Estimate against measurement, compound 3: 3.6-fold (0.55 log units) above; measured number below the stated range.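

In this assay, inverting both stereocentres gives an at least 3.5-fold lower number from compound 2 to compound 3 (0.55 log units; beyond the scatter), so the drawn configuration at the saturated ring carbons matters in this series, which the two earlier limits could not show: the fact that compounds 2 and 3 differ only in the configuration as drawn

With the configuration as drawn unchanged, chloro in place of hydrogen on an aromatic carbon gives an at least 3.5-fold lower number from compound 1 to compound 3 (0.55 log units; beyond the scatter), so this change also has a readable effect in that configuration. On these data alone, compound 1 and compound 2 each stand only at a limit of the assay, so the full size of both steps stays unknown.

The compounds shown leave open whether another group, such as fluoro or methoxy, would serve in place of the chloro. They also leave open how a carboxylic acid or an amine in place of the ethyl ester would read in this assay.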